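The compounds below may be only part of what the source reports. "The series", "measured", "known", "first", "only" and "open" are said of these compounds alone.

Compound 1 `COc1ccc(C2C(C#N)=C(N)N(c3cc(OC)c(OC)c(OC)c3)C3=C2C(=O)CC(C)(C)C3)cc1` gives 15% in a functional assay on Ehrlich cells (Mus musculus) for cytotoxicity, tested at 100 ug/mL; on this read-out lower numbers stand for a weaker effect and higher numbers for a stronger effect at the one concentration tested.
Compound 2 `COc1cc(N2C(N)=C(C#N)C(c3ccccc3O)C3=C2CC(C)(C)CC3=O)cc(OC)c1OC` gives 10%.
Compound 3 `COc1cc(N2C(N)=C(C#N)C(c3cccc([N+](=O)[O-])c3)C3=C2CC(C)(C)CC3=O)cc(OC)c1OC` gives 30%.

Compound 3 stands highest of the three numbers in this assay: the nearest is compound 1, and the step of a number 15 percentage points higher from compound 1 to compound 3 (beyond the scatter) lies beyond the scatter, while the step of a number 20 percentage points higher from compound 2 to compound 3 (beyond the scatter) is the larger gap. Compound 4 `COc1cc(N2C(N)=C(C#N)C(c3ccc(C)cc3)C3=C2CC(C)(C)CC3=O)cc(OC)c1OC` has not yet been measured. It differs from compound 3 in one place: 4-methylphenyl in place of 3-nitrophenyl on a saturated ring carbon. Among the compounds with values here, the steps that bear on this change are those in which the 3-nitrophenyl entered: a number 15 percentage points higher from compound 1 to compound 3 (beyond the scatter) and a number 20 percentage points higher from compound 2 to compound 3 (beyond the scatter), both modest rises. The step of a number 5 percentage points lower from compound 1 to compound 2 (within the scatter) shows that the two aryl groups without the nitro group sit within the scatter of each other. Removing the 3-nitrophenyl is therefore expected to undo a modest rise, so that compound 4 is estimated to fall by a number 15 percentage points lower from compound 3 to compound 4 (beyond the scatter), landing near the values of compound 1 and compound 2. Compound 4 is thus estimated at 15%, with a range from 5% to 28%.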

Compound 4, a percentage reported as activity, at one concentration (the size of the read-out at that concentration, not a potency): 90%
Beside the measured number, compound 4's estimate is 75 percentage points below it; the whole stated range lies below it.
By their numbers in this assay, from the lowest: compounds 2 and 1 (each within the scatter of the next); then compound 3; then compound 4.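

In this assay, within the data shown here, the aryl group on this saturated ring carbon turns out to matter far more than the earlier compounds suggested: their numbers spanned only modest steps, whereas 4-methylphenyl gives a number 60 percentage points higher from compound 3 to compound 4 (beyond the scatter) and a number 80 percentage points higher from compound 2 to compound 4 (beyond the scatter). Among these compounds, the clearest comparison is a number 75 percentage points higher from compound 1 to compound 4 (beyond the scatter), where methyl in place of methoxy on an aromatic carbon is the only change, so the 3-nitrophenyl group is not needed for a high number. Nothing available here accounts for this large rise.

The compounds shown leave open whether methyl is special or whether an ethyl group or a chlorine atom on the same aromatic carbon would serve equally well. With only one concentration tested, they also leave the potency of compound 4 open.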